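The source may hold more compounds than are shown below. What is called first, only, known or untested is meant among the compounds shown, and "the series" means these compounds.

Compound 1, `Cn1c(Cc2ccccc2C(F)(F)F)nc(C(=O)CCc2ccccc2)c(O)c1=O`: in an ADME assay on HepG2 cells (Homo sapiens) for cytotoxicity, in the presence of a further agent that is not named here (on this read-out lower numbers stand for stronger inhibition and higher numbers for weaker inhibition), compound 1 reaches only the limit > 100000 nM.
Compound 2, `Cn1c(Cc2ccccc2C(F)(F)F)nc(C(=O)NCc2ccccc2)c(O)c1=O`: in this assay compound 2 likewise gives only the limit > 100000 nM.
Compound 3, `CC(NC(=O)c1nc(Cc2ccccc2C(F)(F)F)n(C)c(=O)c1O)c1ccccc1`: in this assay compound 3 also stops at the limit > 100000 nM.

Compound 3 therefore stands where every measured compound stands, at the limit (the limit of > 100000 nM in this assay, at which 3 of the 3 values shown sit), and no number is known for it. The three steps among the measured compounds, a step that the two limits leave unreadable from compound 1 to compound 2, a step that the two limits leave unreadable from compound 1 to compound 3 and a step that the two limits leave unreadable from compound 2 to compound 3, are all unreadable for the same reason, so none of them shows a direction.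

Compound 4, `Cn1c(Cc2ccccc2C(F)(F)F)nc(C(=O)NCc2ccccc2F)c(O)c1=O`, differs from compound 3 in one place: 2-fluorobenzyl in place of 1-phenylethyl on an amide-type nitrogen. For the measured compounds named here, the step that bears most directly on this change is a step that the two limits leave unreadable from compound 2 to compound 3, since it concerns the same carbon bound to the amide-type nitrogen; the further fluorine on the ring has no counterpart among the measured steps. Going by the values given here, as that step is unreadable, no size of step in this assay can be expected with confidence, and nothing here argues for a move below the limit.

Compound 4 is therefore estimated at 150000 nM, with a range from 70000 nM to 400000 nM. The expected step is a step that the limit leaves unreadable from compound 3 to compound 4, which would most likely again be left unreadable by the limit.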

Compound 4, half-maximal inhibitory concentration: > 100000 nM
Compound 4 gave a limit, no number (the forecaster's own chance of this, stated with the estimate: 85%); the middle value lies beyond the limit too.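

Compound 4 stands at a limit, as compounds 1, 2 and 3 do, so none of its steps to those compounds can be read in this assay: the limit of > 100000 nM in this assay, at which 4 of the 4 values shown sit.

The compounds shown leave open how far any of the four lies beyond that limit, and whether any change among them, including fluoro in place of hydrogen from compound 2 to compound 4, alters the read-out.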